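Methyl for phenyl on the carboxamide nitrogen

The compounds below may be only part of what the source reports. "The series", "measured", "known", "first", "only" and "open" are said of these compounds alone.

In an assay on isolated protein for inhibition of alkaline phosphatase, tissue-nonspecific isozyme (Homo sapiens) (a higher number here means a weaker inhibitor, a lower number a stronger inhibitor), compound 1 `COc1ccc(Cl)cc1S(=O)(=O)Nc1cncc(C(=O)Nc2ccccc2)c1` stands at "not determined" (no result reported); no result for it is known. Around it, compound 2 `COc1ccc(F)cc1S(=O)(=O)Nc1cncc(C(N)=O)c1` gives 109 nM in this assay, and compound 3 `COc1ccc(Cl)cc1S(=O)(=O)Nc1cnc2ccccc2c1`, with a different core, gives 4510 nM. Compound 4 `CNC(=O)c1cncc(NS(=O)(=O)c2cc(Cl)ccc2OC)c1` is not yet measured. It differs from compound 1 by methyl in place of phenyl on an amide-type nitrogen. With no number for compound 1, the step to compound 4 cannot be sized or given a direction in this assay; it is expected to land where the small carboxamide of compound 2 lands rather than where compound 3 does. Compound 4 is therefore estimated at 200 nM in this assay, with a likely range from 50 nM to 1000 nM, because compound 2 gives 109 nM.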

Compound 4, half-maximal inhibitory concentration: > 20000 nM
Compound 4: a limit, no number (the forecaster's own chance of this, stated with the estimate: 5%); middle value at least 100-fold (2.00 log units) from the limit.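

In this assay compound 4 gives > 20000 nM, a limit and not a number. Going by these compounds alone, compound 1 has no number either, so no step between compound 1 and compound 4 can be read. The compounds shown leave open how phenyl and methyl on the amide-type nitrogen compare.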